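Plasma Stability of Isosorbide Diesters: Estimating Compound 4

A few compounds are considered here, and "the series" means these few. Any claim that something is new, unique, unknown or untested is made for them only; others in the source may bear on it.

Measured compounds:
compound 1 `COc1ccccc1C(=O)O[C@@H]1CO[C@H]2[C@@H]1OC[C@@H]2OC(=O)c1ccccc1OC(C)=O`: 0.0578 h
compound 2 `CC(=O)Oc1ccccc1C(=O)O[C@H]1CO[C@H]2[C@@H]1OC[C@H]2OC(=O)c1ccccc1OC(=O)c1ccccc1`: 0.385 h
compound 3 `CC(=O)Oc1ccccc1C(=O)O[C@H]1CO[C@H]2[C@@H]1OC[C@H]2O[N+](=O)[O-]`: 0.0144 h

In an ADME assay on a cell-free system (plasma, Homo sapiens) for metabolic stability, with Plasma (Rattus norvegicus) as the target, read by HPLC, at pH 7.4 (on this read-out higher numbers stand for a longer-lived compound and lower numbers for a shorter-lived compound), compound 1 gives 0.0578 h, the second highest of the three numbers. Its nearest neighbour is compound 3, reached by a 4.0-fold lower number from compound 1 to compound 3 (0.60 log units; beyond the scatter); the furthest is compound 2, reached by a 6.7-fold higher number from compound 1 to compound 2 (0.82 log units; beyond the scatter). Compound 4 `CC(=O)Oc1ccccc1C(=O)O[C@H]1CO[C@H]2[C@@H]1OC[C@H]2OC(=O)c1ccc(CO[N+](=O)[O-])cc1` has not yet been measured in this assay. It differs from compound 1 in one place: 4-((nitrooxy)methyl)phenyl in place of 2-methoxyphenyl on a carbonyl carbon. For the measured compounds named here, no measured step alters the aryl group of this ester in the same way. The step to compound 3 removes the whole ester and brings in a nitro group, and the step to compound 2 changes the other aromatic ring, so both are only loosely related. With nothing pointing firmly in either direction, the step to compound 4 is expected to stay small, a 1.0-fold higher number from compound 1 to compound 4 (0.02 log units; within the scatter), with a wide range. Compound 4 is therefore estimated at 0.06 h, between 0.02 h and 0.2 h.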

Compound 4, half-life: 0.1 h
Estimate against measurement, compound 4: 1.7-fold (0.22 log units) below; low and high end bracket the measured number.
By their numbers in this assay, from the lowest: compound 3; then compounds 1 and 4 (each within the scatter of the next); then compound 2.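

In this assay, the change of aryl group on this ester carbonyl gives a 1.7-fold higher number from compound 1 to compound 4 (0.24 log units; within the scatter), so at this place 4-((nitrooxy)methyl)phenyl and 2-methoxyphenyl cannot be told apart on half-life. This is the only step shown that keeps the ester and alters just its aryl group, and it stays within the scatter, whereas replacing the whole ester with nitro gives a 4.0-fold lower number from compound 1 to compound 3 (0.60 log units; beyond the scatter), which lies beyond it. No supporting measurement bears on this result.

The compounds shown leave open whether the half-life would also hold with a plain phenyl at this place, or with an amine or a carboxylic acid on the ring. They also leave open what a longer chain in place of the (nitrooxy)methyl group would do.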